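A few compounds are considered here, and "the series" means these few. Any claim that something is new, unique, unknown or untested is made for them only; others in the source may bear on it.

Working notes on the series. Compound 1 `CCCC(C#CC(=O)OC)O/C=C/C(=O)OC` gives 270 nM in a functional assay on HBL-100 cells (Homo sapiens) for antiproliferative activity, read by sulforhodamine B assay, with a stated time of 48 h (a higher number here means a weaker inhibitor of growth, a lower number a stronger inhibitor of growth), and so stands at one end of the two numbers recorded so far, with compound 2 at the other end, the two within the scatter of each other. Compound 2 `COC(=O)C#CC(O/C=C/C(=O)OC)C(C)C` gives 450 nM in this assay; the step of a 1.7-fold higher number from compound 1 to compound 2 (0.22 log units; within the scatter) exchanges isopropyl for propyl on a saturated chain carbon bound to an oxygen on an unsaturated carbon and a triple-bonded carbon and stays within the scatter.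

Compound 3 `COC(=O)C#CC(C[C@@H](C)CCC=C(C)C)O/C=C/C(=O)OC` is the next candidate. It differs from compound 1 by 4-methylpent-3-en-1-yl in place of hydrogen on a saturated chain carbon bound to two saturated chain carbons. Within the data shown here, the only measured step, from compound 1 to compound 2, reshapes the chain at the carbon bearing the oxygen and was within the scatter, so it bears only loosely on a change that lengthens the chain further out. Among the measured compounds shown here, no measured step tests an addition of this size. The expectation is therefore a step of a 1.5-fold higher number from compound 1 to compound 3 (0.17 log units; within the scatter) in this assay of no clear direction and not confidently beyond the scatter. Compound 3 is estimated at 400 nM, with a range from 120 nM to 1500 nM.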

Compound 3, concentration for 50% growth inhibition: 3100 nM
The estimate for compound 3 lay 7.8-fold (0.89 log units) below the measured number; the measured number lies above the stated range.
By their numbers in this assay, from the lowest: compounds 1 and 2 (each within the scatter of the next); then compound 3.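

In this assay, the entry of 4-methylpent-3-en-1-yl in place of hydrogen on a saturated chain carbon bound to two saturated chain carbons gives an 11-fold higher number from compound 1 to compound 3 (1.06 log units; beyond the scatter), so at this place the series does not hold its number when this group is added. The earlier change, isopropyl in place of propyl, gave only a 1.7-fold higher number from compound 1 to compound 2 (0.22 log units; within the scatter), which means that the chain tolerated that exchange but that this tolerance does not extend to the present addition. Nothing measured bears on the origin of this loss of growth inhibition, and the result shows only its size for this one group at this one place.

With a single group at this place, the compounds shown leave open whether the step follows from the length of the added chain, its branching or its double bond, a question that a methyl group or a saturated 4-methylpentyl group there would address. From the compounds shown here alone, whether a hydroxyl or an amine at the end of such a chain would give a different number also remains open.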